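The compounds below may be only part of what the source reports. "The series", "measured", "known", "first", "only" and "open" are said of these compounds alone.

Among the compounds with values here, compound 1 `COc1cc2c(Oc3ccc(NC(=O)c4nn(-c5cccc(F)c5)c(=O)cc4C)cc3F)ccnc2cc1OCCCN1CCC(C)CC1` is one of two compounds measured in a functional assay on HT-29 cells (Homo sapiens) for inhibition, read by MTT assay, with a stated time of 72 h; a lower number here means a stronger inhibitor, a higher number a weaker inhibitor. In this assay compound 1 gives 300 nM, the higher of the two numbers, and its nearest neighbour is compound 2 `COc1cc2c(Oc3ccc(NC(=O)c4nn(-c5cccc(F)c5)c(=O)cc4C)cc3F)ccnc2cc1OCCCN1CCN(C)CC1`, which in this assay gives 250 nM. Within the data shown here, the one measured step, a 1.2-fold lower number from compound 1 to compound 2 (0.08 log units; within the scatter), exchanges the ring at the end of the saturated chain and leaves the two compounds indistinguishable within the usual spread of repeat measurements.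

Compound 3 `COc1cc2c(Oc3ccc(NC(=O)c4nn(-c5ccc(Cl)cc5Cl)c(=O)cc4C)cc3F)ccnc2cc1OCCCN1CCC(C)CC1` is not yet measured. It differs from compound 1 at a different place: 2,4-dichlorophenyl in place of 3-fluorophenyl on an aromatic nitrogen. Among the measured compounds shown here, no measured step touches this aromatic nitrogen or the ring attached to it, so the measured pair from compound 1 to compound 2 says nothing about how this exchange will act, and there is no basis for expecting a move in either direction.

The number for compound 3 is therefore expected to sit close to that of compound 1, with a wide margin of uncertainty, as an estimated step of a 1.1-fold higher number from compound 1 to compound 3 (0.03 log units; within the scatter). Compound 3 is estimated at 320 nM, within a range from 80 nM to 1300 nM.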

Compound 3, half-maximal inhibitory concentration: 170 nM
The estimate for compound 3 lay 1.9-fold (0.27 log units) above the measured number, within the range that was stated.
By their numbers in this assay, from the lowest: compounds 3, 2 and 1 (each within the scatter of the next).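

In this assay, putting 2,4-dichlorophenyl in place of 3-fluorophenyl on the aromatic nitrogen gives a 1.8-fold lower number from compound 1 to compound 3 (0.25 log units; within the scatter) and so cannot be told apart from repeat measurements of a single compound. Within the data shown here, this is the first measured step at this position, and it shows that a ring with two chlorine atoms can replace a ring with one fluorine atom without a difference beyond the scatter, just as the step at the end of the saturated chain stayed within it. Nothing measured here offers an explanation for the size of this step.

The exchange removes the fluorine and adds both chlorine atoms in one move, so a single step cannot show what each substituent contributes on its own. As far as these compounds go, it also remains open what a plain phenyl ring or a pyridine ring would give on this nitrogen, and whether 2,4-dichlorophenyl would give a similar number with 4-methylpiperazin-1-yl at the end of the chain.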